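A few compounds are considered here, and "the series" means these few. Any claim that something is new, unique, unknown or untested is made for them only; others in the source may bear on it.

Measured compounds in a functional assay on the whole organism with Rattus norvegicus as the target, at a dose of 100 mg/kg; a higher number here means more inhibition at the dose given (going by the name of the read-out), a lower number less inhibition:
- compound 1, `N#CNC(=N)NCCCCCn1nc(-c2ccccc2)ccc1=O`: 31%
- compound 2, `C/N=C(/NC#N)NCCCCCCn1nc(-c2ccccc2)ccc1=O`: 31.7%
- compound 3, `CC/N=C(/NC#N)NCCCCCCn1nc(-c2ccccc2)ccc1=O`: 29.1%

Compound 1 stands second highest of the three numbers in this assay. Its nearest neighbour is compound 2, with a number 0.7 percentage points higher from compound 1 to compound 2 (within the scatter); its furthest is compound 3, with a number 1.9 percentage points lower from compound 1 to compound 3 (within the scatter). Between compound 2 and compound 3 the step is a number 2.6 percentage points lower from compound 2 to compound 3 (within the scatter). All three measured steps lie within the scatter, so the three compounds cannot be told apart on these numbers.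

Compound 4, `C/N=C(\S)NCCCn1nc(-c2ccccc2)ccc1=O`, is not yet measured. Against compound 1 the change is:

a group of 5 heavy atoms (2 carbon, 2 nitrogen, 1 sulfur; no ring) in place of a group of 8 heavy atoms (4 carbon, 4 nitrogen; no ring), on a saturated chain carbon, three bonds along the chain from an aromatic nitrogen

Among the measured compounds shown here, none of the measured steps touches this change: each of them alters the group on the chain carbon five bonds from the aromatic nitrogen, and each stays within the scatter. Nothing in the series therefore points to a step beyond the scatter in either direction, but the change to compound 4 is larger than any measured one, so the range is kept wide. Compound 4 is expected to give about 30%, between 15% and 45%, which is an estimated step of a number 1 percentage points lower from compound 1 to compound 4 (within the scatter).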

Compound 4, a percentage reported as inhibition, in the whole organism at one dose (the size of the read-out at that dose, not a potency): 38.9%
For compound 4 the middle estimate is 8.9 percentage points below the measured one, within the range that was stated.
By their numbers in this assay, from the lowest: compounds 3, 1, 2 and 4 (each within the scatter of the next).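

In this assay, putting the group of 5 heavy atoms (2 carbon, 2 nitrogen, 1 sulfur; no ring) in place of the group of 8 heavy atoms (4 carbon, 4 nitrogen; no ring), on a saturated chain carbon, three bonds along the chain from an aromatic nitrogen, gives a number 7.9 percentage points higher from compound 1 to compound 4 (within the scatter). Among the compounds shown here, the earlier steps only varied the group on the chain carbon five bonds along the chain, so this is the first sign that a much larger change, one that brings in sulfur and removes the nitrile, still leaves the read-out inside the scatter of the series. The change alters the group and its place along the chain together, so the two contributions cannot be separated, and no measurement available here bears on the result.

Open, from the compounds shown here alone, is how an amine or a carboxylic acid would read in place of this group at the same place, and whether the sulfur-bearing group would read alike on a longer chain. A read-out at one dose gives the size of the inhibition and not a potency, so any potency difference among these compounds remains unresolved.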